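The source may hold more compounds than are shown below. What is called first, only, known or untested is meant among the compounds shown, and "the series" means these compounds.

In a functional assay on HeLa cells (Homo sapiens) for antiproliferative activity, read by MTT assay, with a stated time of 48 h (a higher number here means a weaker inhibitor of growth, a lower number a stronger inhibitor of growth), compound 1 `CCOc1cc(NC(=O)CCCCC(=O)Nc2cc(-c3ccccc3)ccc2N)cc2c1OCC([N+](=O)[O-])=C2` gives > 20000 nM, which is a limit of the assay and not a number. Among the measured compounds shown here, compound 2 `CCOc1cc(NC(=O)CCCCCCC(=O)Nc2cc(-c3ccccc3)ccc2N)cc2c1OCC([N+](=O)[O-])=C2` gives 16200 nM, the only true number available so far, so it has no measured neighbour against which its place can be fixed precisely. Compound 3 `CCOc1cc(NC(=O)CCCCCCC(=O)Nc2cc(-c3ccc(C)s3)ccc2N)cc2c1OCC([N+](=O)[O-])=C2` keeps the shared core and chain of compound 2 and changes one group: 5-methylthiophen-2-yl in place of phenyl on an aromatic carbon, para to an amino group (5-methylthiophen-2-yl in place of phenyl on an aromatic carbon). For the measured compounds named here, no measured pair in this set tests such an exchange, so the expectation is a cautious one. One aromatic ring replaces another, and only a small step toward stronger growth inhibition is expected in this assay, a 1.9-fold lower number from compound 2 to compound 3 (0.28 log units; within the scatter). Compound 3 is estimated at 8500 nM, with an expected range of 2500 nM to 22000 nM.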

Compound 3, concentration for 50% growth inhibition: > 20000 nM
Compound 3 gave a limit, no number (the forecaster's own chance of this, stated with the estimate: 12%); at least 2.3-fold (0.37 log units) between middle value and limit.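

In this assay compound 3 gives > 20000 nM, a limit of the assay and not a number. Among the compounds shown here, this is the first look at a change at this position, on the aromatic carbon para to an amino group, and 5-methylthiophen-2-yl in place of phenyl brings no gain in growth inhibition: the result is an at least 1.2-fold higher number from compound 2 to compound 3 (0.09 log units; that floor lies within the scatter). The true size of this step cannot be read, because the readings stop at a ceiling: the limit of > 20000 nM in this assay, at which 2 of the 3 values shown sit.

On these data alone, whether an unsubstituted thiophene ring, a pyridine ring or a phenyl ring carrying a fluorine or a methoxy group at this position would give a true number in this assay stays open. So does whether a longer chain than that of compound 2 would shift the reading for either aromatic group.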